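This account rests on a few compounds, and the source may have more. Where it says the series, first, only, none or still open, it means among the compounds named here.

Compound 1 `Cc1ccc(S(=O)(=O)N2CC(O)C[C@H]2C(=O)Nc2ccc(C(=O)O)cc2)cc1` gives 67.2% in a functional assay on the whole organism for inhibition, with Rattus norvegicus as the target, read by paw edema, with stated times of 1 h and 2 h, at a dose of 100 mg/kg by the oral route (a lower number here means less inhibition, a higher number more inhibition at the dose given (going by the name of the read-out)), the highest of the three numbers recorded there. Compound 2 `O=C(O)c1ccc(NC(=O)[C@@H]2CC(O)CN2S(=O)(=O)c2ccccc2)cc1` gives 27.3%, and compound 3 `Cc1ccccc1S(=O)(=O)N1CCC[C@H]1C(=O)Nc1ccc(C(=O)O)cc1` gives 36.3%; both lie beyond the scatter below compound 1.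

Compound 4 `Cc1ccc(S(=O)(=O)N2CCC[C@H]2C(=O)Nc2ccc(C(=O)O)cc2)cc1` differs from compound 1 in one place: hydrogen in place of hydroxy on a saturated ring carbon.

For the measured compounds named here, no measured step shows this same change. Going by the values given here, the one recorded step, a number 39.9 percentage points lower from compound 1 to compound 2 (beyond the scatter), concerns a different change, hydrogen in place of methyl on an aromatic carbon, so it does not bear directly on the hydroxy removal. With no direct guide, the step is expected to be small, possibly none beyond the scatter, with some chance of loss.

For compound 4 the expected value is 55%, within 30% to 75%, a step of a number 12.2 percentage points lower from compound 1 to compound 4 (beyond the scatter) that is estimated rather than measured.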

Compound 4, a percentage reported as inhibition, in the whole organism at one dose (the size of the read-out at that dose, not a potency): 36.3%
The estimate for compound 4 lay 18.7 percentage points above the measured number, and the stated range covers the measured number.
By their numbers in this assay, from the lowest: compounds 2, 3 and 4 (each within the scatter of the next); then compound 1.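

In this assay, hydrogen in place of hydroxy on this saturated ring carbon gives a number 30.9 percentage points lower from compound 1 to compound 4 (beyond the scatter), so with 4-methylphenyl on the sulfonyl sulfur, this hydroxy counts for much of the inhibition. Without the hydroxy, 4-methylphenyl in place of 2-methylphenyl on the sulfonyl sulfur shows no change at the digits printed from compound 3 to compound 4 (within the scatter). Nothing available explains the loss.

The compounds shown leave open whether a methoxy or an amine on that ring carbon would keep the inhibition. They also leave open whether the hydroxy counts as much with 2-methylphenyl on the sulfonyl sulfur.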